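Compound 3: isopropylamino in place of piperazin-1-yl

This account rests on a few compounds, and the source may have more. Where it says the series, first, only, none or still open, it means among the compounds named here.

Compound 1 `FC(F)(F)c1ccc(Nc2ncnc3sc(Nc4c(Cl)cccc4Cl)nc23)cc1` gives 12 nM in a functional assay on HEK293 cells for antagonist activity at transient receptor potential cation channel subfamily V member 1 (Homo sapiens), read by calcium flux; on this read-out lower numbers stand for stronger inhibition and higher numbers for weaker inhibition. Within the data shown here, compound 2 `FC(F)(F)c1ccc(Nc2nc(N3CCNCC3)nc3sc(Nc4c(Cl)cccc4Cl)nc23)cc1` carries piperazin-1-yl on an aromatic carbon of the shared core and gives 5000 nM in this assay; of the two numbers so far this is the higher one, separated from compound 1 by a 420-fold higher number from compound 1 to compound 2 (2.62 log units; beyond the scatter). Compound 3 `CC(C)Nc1nc(Nc2ccc(C(F)(F)F)cc2)c2nc(Nc3c(Cl)cccc3Cl)sc2n1` differs from compound 2 by isopropylamino in place of piperazin-1-yl on an aromatic carbon. Among the measured compounds shown here, the only measured step that bears on this place is the one from compound 1 to compound 2, a 420-fold higher number from compound 1 to compound 2 (2.62 log units; beyond the scatter), which shows that a substituent on this carbon can move the number a long way. Compound 3 still carries a substituent there, so a full return to the number of compound 1 is not expected; a partial return is the expectation. For compound 3 the estimate in this assay is 1000 nM, with a range of 200 nM to 5000 nM. The expected step is therefore a 5.0-fold lower number from compound 2 to compound 3 (0.70 log units; beyond the scatter), toward lower numbers.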

Compound 3, half-maximal inhibitory concentration: 13 nM
Estimate against measurement, compound 3: 77-fold (1.89 log units) above, and the stated range ends above it.
By their numbers in this assay, from the lowest: compounds 1 and 3 (each within the scatter of the next); then compound 2.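

In this assay, isopropylamino in place of piperazin-1-yl gives a 380-fold lower number from compound 2 to compound 3 (2.59 log units; beyond the scatter), and against the hydrogen of compound 1 the same group gives a 1.1-fold higher number from compound 1 to compound 3 (0.03 log units; within the scatter). The aromatic carbon between two ring nitrogen atoms can therefore carry a substituent without a step beyond the scatter, so the large step seen earlier is tied to piperazin-1-yl and not to substitution on this carbon as such. No measurement at hand gives a reason for the gap between these two groups.

Piperazin-1-yl and isopropylamino differ at once in the ring, the heavy atoms and the nitrogen count, so which of these differences sets the number stays open. Piperidin-1-yl, morpholin-4-yl or a longer chain such as n-butylamino on this carbon would bear on that question.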